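From ethyl to phenyl on the shared core

The compounds below may be only part of what the source reports. "The series", "measured", "known", "first", "only" and "open" are said of these compounds alone.

- compound 1 `CCCCc1ccc2[nH]cc(C(=O)OC)c(=O)c2c1` gives > 20000 nM (a limit)
- compound 2 `COC(=O)c1c[nH]c2ccc(OC)cc2c1=O` gives 6180 nM
- compound 3 `CCc1ccc2[nH]cc(C(=O)OC)c(=O)c2c1` gives > 20000 nM (a limit)

All three were tested in an ADME assay on J774 cells (Mus musculus) for cytotoxicity; a lower number here means that less compound is needed, a higher number that more compound is needed for the effect. Compound 3 sits at the limit of > 20000 nM in this assay, at which 2 of the 3 values shown sit, so it has a limit and not a number.

Compound 4 `COC(=O)c1c[nH]c2ccc(-c3ccccc3)cc2c1=O` carries phenyl in place of ethyl on an aromatic carbon.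

Within the data shown here, no phenyl compound has been measured, so the nearest guides are changes at the same place. Going from methoxy to ethyl gave an at least 3.2-fold higher number from compound 2 to compound 3 (0.51 log units; beyond the scatter), and going from butyl to methoxy gave an at least 3.2-fold lower number from compound 1 to compound 2 (0.51 log units; beyond the scatter). Butyl and ethyl cannot be told apart, as a step that the two limits leave unreadable from compound 1 to compound 3 shows. Compound 2 alone gives a number, 6180 nM, so only a modest step to a lower number is expected. Compound 4 may well stay at the limit. The expected step is an at least 1.4-fold lower number from compound 3 to compound 4 (0.15 log units; that floor lies within the scatter). For compound 4 the estimate is 14000 nM, with an expected range from 5000 nM to 30000 nM.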

Compound 4, half-maximal effective concentration: > 20000 nM
Compound 4 gave a limit, no number; the forecaster's own chance of this, stated with the estimate: 55%; middle value at least 1.4-fold (0.15 log units) away from the limit.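

In this assay, phenyl in place of methoxy gives an at least 3.2-fold higher number from compound 2 to compound 4 (0.51 log units; beyond the scatter). A ring at this aromatic carbon therefore joins ethyl and butyl, and among the four groups shown, only methoxy gives a number rather than a limit. The steps among compound 1, compound 3 and compound 4 cannot be read, because all three sit at the same limit: the limit of > 20000 nM in this assay, at which 3 of the 4 values shown sit.

From the compounds shown here alone, whether an ethoxy group or an amine at this carbon would also give a number stays open. Going by these compounds, how far phenyl, ethyl and butyl really differ also stays open.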